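Methyl on the phenolic oxygen of compound 1

The compounds below may be only part of what the source reports. "The series", "measured", "known", "first", "only" and "open" are said of these compounds alone.

Measured so far in a functional assay on cells (Cancer cell lines, Homo sapiens) for cytotoxicity, with a stated time of 48 h; on this read-out higher numbers stand for weaker inhibition of growth and lower numbers for stronger inhibition of growth:
compound 1, `COc1cc2c(/C=C3/C(=O)Nc4ccc(O)cc43)c(Cl)n(Cc3cc(OC)c(OC)c(OC)c3)c2cc1C`, 34700 nM
compound 2, `O=C1/C(=C/c2c(Cl)[nH]c3ccccc23)c2ccccc2N1Cc1ccccc1`, 69200 nM
compound 3, `COc1c(/C=C2/C(=O)Nc3ccccc32)c2ccccc2n1-c1ccccc1`, 8510 nM

Compound 1 stands second highest of the three numbers. Its nearest neighbour is compound 2, whose number lies within the scatter of that of compound 1, so no order between them can be claimed. Compound 3 gives a lower number, and that gap lies beyond the scatter.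

Compound 4, `COc1ccc2c(c1)/C(=C\c1c(Cl)n(Cc3cc(OC)c(OC)c(OC)c3)c3cc(C)c(OC)cc13)C(=O)N2`, differs from compound 1 in one place: methyl in place of hydrogen on an oxygen on an aromatic ring. Among the measured compounds shown here, no step between two measured compounds shows what this change does in this assay, so the expectation rests on compound 1 alone. Compound 4 is expected to move little, with a step of a 1.0-fold higher number from compound 1 to compound 4 (0.00 log units; within the scatter) that stays within the scatter. Compound 4 is thus estimated at 35000 nM, between 12000 nM and 100000 nM.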

Compound 4, concentration for total growth inhibition: 75900 nM
Estimate against measurement, compound 4: 2.2-fold (0.34 log units) below; the measured number falls inside the stated range.
By their numbers in this assay, from the lowest: compound 3; then compounds 1, 2 and 4 (each within the scatter of the next, the first and the last beyond it).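

In this assay the change from hydroxy to methoxy gives a 2.2-fold higher number from compound 1 to compound 4 (0.34 log units; beyond the scatter) and so weakens growth inhibition modestly, which makes the free hydroxy the better of these two groups at this position. Among the compounds shown here, this is the first reading of any single change here, since the earlier compounds offered no pair differing in one place. Nothing available explains the shift.
On these data alone, whether an ethyl group on this oxygen, or an amine in place of the hydroxy, would follow the same direction stays open, as does whether this step holds on another core.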